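The source may hold more compounds than are shown below. What is called first, only, known or untested is meant among the compounds shown, and "the series" means these compounds.

Three esters of a shared core have been tested in a functional assay on SiHa cells (Homo sapiens) for antiproliferative activity, read by MTT assay, with a stated time of 48 h; on this read-out higher numbers stand for weaker inhibition and lower numbers for stronger inhibition. In this assay compound 1 (`C/C(=C\CC/C(C)=C/CC[C@@H]1[C@@]2(C)CCC(=O)C(C)(C)[C@H]2CC[C@@]1(C)O)CC/C=C(\C)C(=O)OCc1cn(C[C@@H]2O[C@H](n3ccc(=O)[nH]c3=O)C[C@H]2O)nn1`) gives 29300 nM and compound 3 (`C/C(=C\CC/C(C)=C/CC[C@@H]1[C@@]2(C)CCC(=O)C(C)(C)[C@H]2CC[C@@]1(C)O)CC/C=C(\C)C(=O)OCc1cn([C@@H]2C[C@@H](n3cc(C)c(=O)[nH]c3=O)O[C@H]2CO)nn1`) gives 41700 nM as its result, while compound 2 (`C/C(=C\CC/C(C)=C/CC[C@@H]1[C@@]2(C)CCC(=O)C(C)(C)[C@H]2CC[C@@]1(C)O)CC/C=C(\C)C(=O)OCc1cn(-c2cccc(Cl)c2)nn1`) gives 111000 nM as the highest number of the three. Compound 2 is thus the weakest inhibitor of this small set, clearly separated from both of the others.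

Compound 4 (`C/C(=C\CC/C(C)=C/CC[C@@H]1[C@@]2(C)CCC(=O)C(C)(C)[C@H]2CC[C@@]1(C)O)CC/C=C(\C)C(=O)OCc1cn(-c2cccc(O)c2)nn1`) departs from compound 2 in a single place, with hydroxy in place of chloro on an aromatic carbon. Among the measured compounds shown here, no measured pair isolates this exchange. The only indirect hint is that compound 1 (29300 nM) and compound 3 (41700 nM) lack the 3-chlorophenyl group and show lower numbers, although each differs from compound 2 in much more than one group.

A small move toward stronger inhibition is therefore expected, and the estimated step is a 1.9-fold lower number from compound 2 to compound 4 (0.27 log units; within the scatter) on this evidence. Compound 4 is estimated at 60000 nM in this assay (expected range 25000 nM to 130000 nM).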

Compound 4, half-maximal inhibitory concentration: 48000 nM
Estimate against measurement, compound 4: 1.3-fold (0.10 log units) above; the measured number falls inside the stated range.
By their numbers in this assay, from the lowest: compounds 1, 3 and 4 (each within the scatter of the next); then compound 2.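

In this assay, hydroxy in place of chloro on an aromatic carbon, meta to a large group, gives a 2.3-fold lower number from compound 2 to compound 4 (0.36 log units; beyond the scatter), a modest step but one beyond the usual scatter. Among the compounds shown here, this is the first direct reading of this position: the earlier compounds differed from one another in much more than one group, whereas here the exchange of a single heavy atom, which adds one hydrogen-bond donor and one acceptor, is enough to move the read-out. The compounds shown offer no measured property that would account for this step.

This single pair cannot separate the loss of chloro from the gain of hydroxy. An unsubstituted phenyl, or a methoxy or an amine at the same place, would help to tell the two apart, and the exchange is seen here only on this one ring position.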